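A few compounds are considered here, and "the series" means these few. Any claim that something is new, unique, unknown or untested is made for them only; others in the source may bear on it.

Compound 1 `Cc1ccc(C(=O)Nc2cc(-c3ccccc3)nn2-c2ccccc2)cc1` was tested in an assay on HEK293 cells for displacement of a labelled ligand from metabotropic glutamate receptor 5 (Rattus norvegicus) (on this read-out higher numbers stand for weaker inhibition and lower numbers for stronger inhibition), and compound 1 gives 780 nM. Of the two numbers recorded, this is the lowest. Compound 3 `O=C(Nc1cc(-c2ccccc2)nn1-c1ccccc1F)c1ccccc1`, which carries a fluorine on the phenyl attached to the ring nitrogen of the shared core, gives 2700 nM in this assay, a gap from compound 1 that lies beyond the usual scatter. Compound 2 `O=C(Nc1cc(-c2ccccc2Cl)nn1-c1ccccc1)c1ccccc1` reaches only a limit of this assay rather than a number, > 10000 nM; that is the limit of > 10000 nM in this assay, at which 1 of the 3 values shown sits.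

Compound 4 `O=C(CC1CCCC1)Nc1cc(-c2ccccc2)nn1-c1ccccc1` has not yet been measured. It differs from compound 1 in one place: cyclopentylmethyl in place of 4-methylphenyl on a carbonyl carbon. The amide of compound 1 is thus attached to an aromatic ring, while in compound 4 it is attached to a saturated chain ending in a ring. Among the measured compounds no step of this kind exists to lean on. The expectation is a step of a 3.8-fold higher number from compound 1 to compound 4 (0.59 log units; beyond the scatter) in this assay, toward weaker binding and beyond the scatter. Compound 4 is therefore estimated at 3000 nM, with a range from 700 nM to 15000 nM.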

Compound 4, inhibition constant: > 10000 nM
Compound 4 was reported as a limit (the forecaster's own chance of this, stated with the estimate: 25%); middle value at least 3.3-fold (0.52 log units) from the limit.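

Changing 4-methylphenyl to cyclopentylmethyl on a carbonyl carbon gives an at least 12-fold higher number from compound 1 to compound 4 (1.10 log units; beyond the scatter) in this assay. For the compounds shown here, this is the first direct reading of this position, and for this pair, the aromatic ring on the amide carbonyl cannot be swapped for a saturated ring on a short chain without a large loss of binding. Compound 4 gives a limit rather than a number, so the step shows only the smallest possible size of that loss: the limit of > 10000 nM in this assay, at which 2 of the 4 values shown sit.

The change replaces an aromatic ring with a saturated one, alters the ring size and moves the ring one carbon away from the carbonyl, all at once, so the compounds shown cannot say which of these counts. A phenylmethyl or a cyclohexyl group on the same carbonyl carbon would help to separate them.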